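Adding Ethyl to an Amide Nitrogen: Two Related Cases

The compounds below may be only part of what the source reports. "The series", "measured", "known", "first", "only" and "open" are said of these compounds alone.

Compound 1 `CCNC(=O)C1=C(C)NC(=O)NC1c1cccs1` and compound 2 `CCN(CC)C(=O)C1=C(C)NC(=O)NC1c1cccs1` share one core, while compound 3 `CC1=C(C(N)=O)C(c2ccsc2)NC(=O)N1` and compound 4 `CCNC(=O)C1=C(C)NC(=O)NC1c1ccsc1` share another; how the core of compound 3 differs from that of compound 1 is not broken down here. In an assay on membranes from HeLa cells for displacement of a labelled ligand from adenosine receptor A3 (Homo sapiens), read by scintillation counting, with a stated time of 180 min, tested at 1 uM (on this read-out higher numbers stand for more inhibition at the one concentration tested (going by the name of the read-out) and lower numbers for less inhibition), compound 1 gives 4%, and compound 2 gives 31%. The change between them is ethyl in place of hydrogen on an amide-type nitrogen, and it made a number 27 percentage points higher from compound 1 to compound 2 (beyond the scatter). Compound 3 gives 1% in this assay, the lowest of the three numbers, although compound 1 sits within the scatter of it. Compound 4 arises from compound 3 by ethyl in place of hydrogen on an amide-type nitrogen. For the measured compounds named here, this is the same kind of change, not the same one: in compound 1 the nitrogen that takes the ethyl has a carbonyl carbon and a saturated chain carbon as its other neighbours, whereas in compound 3 its only other neighbour is a carbonyl carbon, so after the change the nitrogen still carries a hydrogen. The step from compound 3 to compound 4 is expected to be a number 4 percentage points higher from compound 3 to compound 4 (within the scatter), smaller than the earlier one, because compound 1 gives only 4% with one ethyl already on such a nitrogen. Compound 4 is therefore estimated at 5%.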

Compound 4, a percentage reported as inhibition, at one concentration (the size of the read-out at that concentration, not a potency): 1%
Estimate against measurement, compound 4: 4 percentage points above; measured number inside the range.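

Ethyl in place of hydrogen on an amide-type nitrogen did not act alike on the two cores in this assay: the same change on two cores in this assay, a number 27 percentage points higher (beyond the scatter) from compound 1 to compound 2 and no change at the digits printed (within the scatter) from compound 3 to compound 4, 27 percentage points apart, beyond the scatter of two such steps. So the rise seen on the first core cannot be carried over to the second as a fixed gain, and here the step reads no change at the digits printed from compound 3 to compound 4 (within the scatter). This does not show why the steps part, since they differ in two ways: the ethyl joins a nitrogen that already has an ethyl in one case and not in the other, and the cores differ by thiophen-3-yl in place of thiophen-2-yl, a swap that by itself reads a number 3 percentage points lower from compound 1 to compound 4 (within the scatter).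

The compounds shown leave open whether a second ethyl on the amide nitrogen of compound 4 would bring a rise like the one seen with compound 2, which would help separate those two differences. They also leave open what a longer chain such as propyl, or a ring amine such as piperidine, would do on that nitrogen.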